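From ethyl to 2-(dimethylamino)ethyl on compound 3

The source may hold more compounds than are shown below. What is called first, only, known or untested is meant among the compounds shown, and "the series" means these compounds.

Of the compounds shown here, three sharing a core have been measured in a functional assay on HUVEC cells (Homo sapiens) for inhibition (on this read-out lower numbers stand for stronger inhibition and higher numbers for weaker inhibition), so far. Compound 1 `CN(c1ccc(NC(=O)Nc2ccccc2)cc1)c1ccnc(Nc2cccc(CS(C)(=O)=O)c2)n1` gives 0.2 nM and stands lowest of the three. Compound 2 `CN(c1ccc(NC(=O)Nc2ccc(OC(F)(F)F)cc2)cc1)c1ccnc(Nc2cccc(S(N)(=O)=O)c2)n1` gives 5 nM on the same read-out. Compound 3 `CCNC(=O)Nc1ccc(N(C)c2ccnc(Nc3ccc(CS(C)(=O)=O)cc3)n2)cc1` gives 27 nM and has the highest number of the three, which makes it the weakest inhibitor of this small set, with both gaps beyond the scatter.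

Compound 4 `CN(C)CCNC(=O)Nc1ccc(N(C)c2ccnc(Nc3ccc(CS(C)(=O)=O)cc3)n2)cc1` has not been measured yet. It differs from compound 3 in one place: dimethylamino stands in place of hydrogen on a saturated chain carbon, two bonds along the chain from an amide-type nitrogen (dimethylamino in place of hydrogen on a saturated chain carbon, two bonds along the chain from an amide-type nitrogen), so ethyl becomes 2-(dimethylamino)ethyl.

For the measured compounds named here, no two measured compounds differ in just one place, so the data hold no direct precedent for this change. Compounds 1 and 2 differ from compound 3 in several places at once and give no clean guide to it. No step beyond the scatter is expected in this assay and neither direction is favoured. The estimated move is a 1.1-fold lower number from compound 3 to compound 4 (0.03 log units; within the scatter) and it is a small one. Compound 4 is expected at 25 nM with an estimated range from 7 nM to 90 nM once it is measured.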

Compound 4, half-maximal inhibitory concentration: 2980 nM
For compound 4 the middle estimate is 120-fold (2.08 log units) below the measured one, outside the stated range (above it).
By their numbers in this assay, from the lowest: compound 1; then compound 2; then compound 3; then compound 4.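

In this assay, for the compounds shown here, placing dimethylamino on a saturated chain carbon, two bonds along the chain from an amide-type nitrogen, gives a 110-fold higher number from compound 3 to compound 4 (2.04 log units; beyond the scatter), the first step in this set where only one place changes, and it means much weaker inhibition. This shows that the ethyl group of compound 3 is not a spot where additions pass without consequence: a single small group on this chain carbon is enough to shift the read-out by a large margin. Nothing measured here explains the size of this step, so its cause remains unknown.

The compounds shown cannot tell whether the loss belongs to dimethylamino itself or would follow any addition at this carbon, since a single pair gives no way to separate the two. A hydroxyl or methoxy group on the same carbon, a plain propyl chain, or a longer chain carrying the same dimethylamino group would each help to separate these possibilities and show how far the sensitivity of this position extends.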